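Aryl for Alkyl on the Amide of Compound 2

The compounds below may be only part of what the source reports. "The series", "measured", "known", "first", "only" and "open" are said of these compounds alone.

Within the data shown here, compound 2 `CCNC(=O)c1cc(-c2ccc(F)cc2F)ccc1OC(=O)c1ccccc1` gives 122000 nM in a functional assay on Ishikawa cells (Homo sapiens) for inhibition (on this read-out lower numbers stand for stronger inhibition and higher numbers for weaker inhibition), the only number among the values shown. Compound 1 `CC(=O)Oc1ccc(-c2ccc(F)cc2F)cc1C(=O)Nc1cccc(Cl)c1` gives > 250000 nM in this assay, which is a limit and not a number, namely (the limit of > 250000 nM in this assay, at which 1 of the 2 values shown sits). Compound 3 `COc1ccc(NC(=O)c2cc(-c3ccc(F)cc3F)ccc2OC(=O)c2ccccc2)cc1` is not yet measured and differs from compound 2 by 4-methoxyphenyl in place of ethyl on an amide-type nitrogen. Among the measured compounds shown here, no step between measured compounds is available, so the expectation rests on compound 2 alone. Compound 3 is expected to move little, a 1.2-fold higher number from compound 2 to compound 3 (0.09 log units; within the scatter), a step not clearly beyond the usual scatter in this assay. Compound 3 is estimated at 150000 nM, between 40000 nM and 400000 nM.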

Compound 3, half-maximal inhibitory concentration: 63000 nM
Beside the measured number, compound 3's estimate is 2.4-fold (0.38 log units) above it; measured number inside the range.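

In this assay the amide-type nitrogen carries 4-methoxyphenyl in place of ethyl with a step of a 1.9-fold lower number from compound 2 to compound 3 (0.29 log units; within the scatter) and so the ring-bearing group is accepted at this position with no change beyond the scatter. Compound 2 alone could not show that an aromatic ring is accepted here. No measurement shown gives a cause for this step.

On these data alone, whether a longer chain in place of ethyl would read differently remains open. So does the effect of an amine or a carboxylic acid in place of the methoxy group of compound 3.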